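This account rests on a few compounds, and the source may have more. Where it says the series, first, only, none or still open, it means among the compounds named here.

Measured compounds:
compound 1 `N#CC1=C(NCN2CCCCC2)N(c2ccccc2)C(=O)N2CCCCC(N3CCCC3)C12` — in a functional assay on the whole organism (strain albino) for inhibition, with Rattus norvegicus as the target, read by paw edema, with stated times of 1 h and 3 h, at a dose of 20 mmol/kg by the intraperitoneal route (on this read-out lower numbers stand for a weaker effect and higher numbers for a stronger effect at the one dose given), compound 1 gives 42.1%
compound 2 `COc1ccc(/C=N/C2=C(C#N)C3C(N4CCCC4)CCCCN3C(=O)N2c2ccccc2)cc1` — in this assay compound 2 gives 75.3%

Compound 2 stands highest of these two numbers, its nearest neighbour being compound 1. Among the measured compounds shown here, the one measured step, a number 33.2 percentage points higher from compound 1 to compound 2 (beyond the scatter), swaps a whole ring-bearing group on a double-bonded ring carbon. Compound 3 `N#CC1=C(/N=C/c2ccc([N+](=O)[O-])cc2)N(c2ccccc2)C(=O)N2CCCCC(N3CCCC3)C12` keeps that group and alters only its far end: nitro in place of methoxy on an aromatic carbon. For the measured compounds named here, no measured step touches a nitro-for-methoxy exchange, so the expected step of a number 3.3 percentage points lower from compound 2 to compound 3 (within the scatter) lies within the scatter. Compound 3 is therefore estimated at 72%, between 55% and 88%.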

Compound 3, a percentage reported as inhibition, in the whole organism at one dose (the size of the read-out at that dose, not a potency): 91.7%
Compound 3: middle estimate off by 19.7 percentage points, on the low side, and the stated range ends below it.
By their numbers in this assay, from the lowest: compound 1; then compound 2; then compound 3.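

Nitro in place of methoxy on an aromatic carbon gives a number 16.4 percentage points higher from compound 2 to compound 3 (beyond the scatter) in this assay, so the far end of the incoming group matters, not just its arrival on the double-bonded ring carbon. With the 4-nitrophenyl end in place, the whole-group swap gives a number 49.6 percentage points higher from compound 1 to compound 3 (beyond the scatter). Nothing available explains this rise.

Among the compounds shown here, only two groups have been compared at this end, so it remains open whether an amine, a chlorine atom or a carboxylic acid on that carbon would give a higher or lower number.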